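Benzyl on the ring nitrogen: outlook for compound 4

The compounds below may be only part of what the source reports. "The series", "measured", "known", "first", "only" and "open" are said of these compounds alone.

Measured so far:
compound 1 `N#Cc1c(-c2ccc(Cl)cc2)nc(SCC(=O)Nn2c(COc3ccc(Cl)cc3Cl)nc3ccccc3c2=O)[nH]c1=O`: 63.6%
compound 2 `N#Cc1c(-c2ccc(O)cc2)nc(SCC(=O)Nn2c(COc3ccc(Cl)cc3Cl)nc3ccccc3c2=O)[nH]c1=O`: 63.6%
compound 3 `O=C(CSc1nc(-c2ccc(O)cc2)c(C(=O)O)c(=O)[nH]1)Nn1c(COc2ccc(Cl)cc2Cl)nc2ccccc2c1=O`: 36.4%

All three were read in a functional assay on the whole organism (strain albino) for inhibition, with Rattus norvegicus as the target, read by paw edema, with a stated time of 1 h, at a dose of 100 mg/kg by the oral route; a lower number here means less inhibition, a higher number more inhibition at the dose given (going by the name of the read-out). Compound 2 stands level with compound 1 at the digits given, and no change at the digits printed from compound 1 to compound 2 (within the scatter) lies within the scatter; together they are the highest of the three numbers. Compound 3 sits furthest from compound 2, with a number 27.2 percentage points lower from compound 2 to compound 3 (beyond the scatter).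

Compound 4 `N#Cc1c(-c2ccc(O)cc2)nc(SCC(=O)Nn2c(COc3ccc(Cl)cc3Cl)nc3ccccc3c2=O)n(Cc2ccccc2)c1=O` differs from compound 2 by benzyl in place of hydrogen on an aromatic nitrogen. On these data alone, neither measured step bears on this change: both alter a group on an aromatic carbon, not on the aromatic nitrogen, so no direction can be drawn from them, and a step in this assay of either sign, or none beyond the scatter, remains open. Compound 4 is therefore expected to give about 58%, with a wide range from 30% to 78%. The expected step is a number 5.6 percentage points lower from compound 2 to compound 4 (within the scatter), estimated to lie within the scatter.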

Compound 4, a percentage reported as inhibition, in the whole organism at one dose (the size of the read-out at that dose, not a potency): 54.6%
Beside the measured number, compound 4's estimate is 3.4 percentage points above it; the measured number falls inside the stated range.
By their numbers in this assay, from the lowest: compound 3; then compounds 4, 1 and 2 (each within the scatter of the next).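

Benzyl in place of hydrogen on the aromatic nitrogen gives a number 9 percentage points lower from compound 2 to compound 4 (within the scatter) in this assay and so shows that this position, untouched in the earlier compounds, accepts a large group without a step beyond the scatter. The hydrogen on this nitrogen is therefore not needed to keep the read-out at this dose. Nothing measured here explains the size of this step.

Still open, on these data alone, is whether a methyl, a longer chain or a benzyl carrying an amine on its ring would hold the read-out at this nitrogen. Also open, as far as these compounds go, is whether benzyl behaves the same way alongside the chloro or carboxy variants of the series.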